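The source may report more compounds than this note shows. Statements on the series, on what has been measured and on what is new or still open speak of the compounds shown alone.

Measured in an ADME assay on MT4 cells (Homo sapiens) for cytotoxicity, read by MTT assay; a lower number here means that less compound is tolerated, a higher number that more compound is tolerated; all three values are limits:
- compound 1 `O=C(CSc1nc(Cc2c(F)cccc2F)cc(=O)[nH]1)c1ccccc1`: > 67000 nM (limit)
- compound 2 `O=C(CSc1nc(Cc2c(Cl)cccc2Cl)cc(=O)[nH]1)c1ccccc1`: > 12000 nM (limit)
- compound 3 `O=C(CSc1nc(Cc2c(Cl)cccc2Cl)cc(=O)[nH]1)c1ccc(F)cc1`: > 59000 nM (limit)

Compound 2 has no exact value, only the limit > 12000 nM. The other two compounds are also known only as limits, so the series has no true number yet.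

The next compound is compound 4 `CC(C)c1c(Cc2c(Cl)cccc2Cl)nc(SCC(=O)c2ccccc2)[nH]c1=O`, which has isopropyl in place of hydrogen on an aromatic carbon of the core of compound 2: isopropyl in place of hydrogen on an aromatic carbon.

Within the data shown here, two measured steps touch compound 2. One is a step that the two limits leave unreadable from compound 1 to compound 2, with 2,6-dichlorophenyl in place of 2,6-difluorophenyl. The other is a step that the two limits leave unreadable from compound 2 to compound 3, with fluoro in place of hydrogen on an aromatic carbon. The second is the closer in kind, as it also replaces a hydrogen on an aromatic carbon, but it lies at another place and involves another group. Neither step has a readable size, so neither supports a direction for the isopropyl change.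

No step beyond the scatter is therefore expected, and the expected step that the limit leaves unreadable from compound 2 to compound 4 is only a working figure. Compound 4 is also likely to be reported as a limit in this assay.

For compound 4 the estimated value is 20000 nM, with an expected range from 6000 nM to 70000 nM.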

Compound 4, half-maximal cytotoxic concentration: > 56000 nM
Compound 4: a limit, no number; the forecaster's own chance of this, stated with the estimate: 70%; at least 2.8-fold (0.44 log units) between middle value and limit.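

In this assay compound 4 gives > 56000 nM, which is a limit. Compound 2 stands at > 12000 nM, also a limit. No step can be read from compound 2 to compound 4. The compounds shown leave open where any true half-maximal cytotoxic concentration lies, and whether isopropyl in place of hydrogen shifts it.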